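The compounds below may be only part of what the source reports. "The series", "measured", "known", "first", "only" and "open" are said of these compounds alone.

Compound 1 `CN1CCCN(CCn2ccc3ccc(F)cc32)CC1` gives 288 nM in an assay on HEK293 cells for binding affinity to 5-hydroxytryptamine receptor 7 (Homo sapiens), read by radioligand binding; a higher number here means a weaker inhibitor, a lower number a stronger inhibitor. Compound 2 `CN1CCCN(CCn2ccc3ccc(Cl)cc32)CC1` gives 34 nM in this assay, and compound 3 `CC(C)c1ccc2ccn(CCN3CCCN(C)CC3)c2c1` gives 145 nM. Among these three numbers compound 3 stands second highest; its steps to the other two are a 2.0-fold lower number from compound 1 to compound 3 (0.30 log units; within the scatter) and a 4.3-fold higher number from compound 2 to compound 3 (0.63 log units; beyond the scatter).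

Compound 4 `CN1CCCN(CCn2ccc3ccc(-c4ccsc4)cc32)CC1` differs from compound 3 in one place: thiophen-3-yl in place of isopropyl on an aromatic carbon. Going by the values given here, the steps that bear on this are the three swaps at the same aromatic carbon, namely an 8.5-fold lower number from compound 1 to compound 2 (0.93 log units; beyond the scatter), a 2.0-fold lower number from compound 1 to compound 3 (0.30 log units; within the scatter) and a 4.3-fold higher number from compound 2 to compound 3 (0.63 log units; beyond the scatter). They show that exchanging the group at this position can move the number by a modest amount, but no aromatic ring has been placed there so far, so neither direction is supported over the other. A step in this assay no larger than modest is therefore expected, with the direction open, so that compound 4 is expected to give 110 nM, within a range of 30 nM to 400 nM, which corresponds to an expected step of a 1.3-fold lower number from compound 3 to compound 4 (0.12 log units; within the scatter).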

Compound 4, inhibition constant: 109 nM
The estimate for compound 4 lay 1.0-fold (0.00 log units) above the measured number; the measured number falls inside the stated range.
By their numbers in this assay, from the lowest: compound 2; then compounds 4, 3 and 1 (each within the scatter of the next, the first and the last beyond it).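

Thiophen-3-yl shows that this aromatic carbon can carry a five-membered aromatic ring without leaving the range set by isopropyl, with a 1.3-fold lower number from compound 3 to compound 4 (0.12 log units; within the scatter) as the step between the two. Chloro still gives the lowest number of the four, as a 3.2-fold higher number from compound 2 to compound 4 (0.51 log units; beyond the scatter) shows, while the aromatic ring, unlike isopropyl, has a step from fluoro that lies beyond the scatter, a 2.6-fold lower number from compound 1 to compound 4 (0.42 log units; beyond the scatter), although compounds 3 and 4 themselves cannot be told apart. Nothing measured on these compounds gives a reason for any of these steps.

As far as these compounds go, whether bromo would follow chloro, and whether phenyl or thiophen-2-yl would match thiophen-3-yl, remains open. The compounds shown also say nothing about an amine, a carboxylic acid or a longer chain on this aromatic carbon.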